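The source may hold more compounds than are shown below. What is called first, only, known or untested is meant among the compounds shown, and "the series" means these compounds.

Measured compounds:
compound 1 `CC(=O)Nc1ccc(Nc2nccc(-c3cccnc3)n2)cc1`: 3600 nM
compound 2 `CC(=O)Nc1ccc(Nc2nccc(-c3ccccn3)n2)cc1`: 1500 nM

In a functional assay for inhibition, with Homo sapiens as the target (a higher number here means a weaker inhibitor, a lower number a stronger inhibitor), compound 1 gives 3600 nM, which is the higher of the two numbers recorded so far. Its nearest neighbour is compound 2, and the move between them is a 2.4-fold lower number from compound 1 to compound 2 (0.38 log units; beyond the scatter), a modest step that lies beyond the scatter. Compound 3 `CNc1ccc(Nc2nccc(-c3cccnc3)n2)cc1` has not yet been measured in this assay. It differs from compound 1 in a single place: methyl in place of acetyl on a nitrogen on an aromatic ring. Within the data shown here, no measured step touches this part of the shared core; the only step available concerns a pyridyl ring in a different part of the molecule and carries no information about the nitrogen on the aromatic ring. With nothing to anchor the change, no step beyond the scatter is expected here: no change at the digits printed from compound 1 to compound 3 (within the scatter). Compound 3 is therefore estimated at 3600 nM, with a range from 1200 nM to 11000 nM, pending the actual reading.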

Compound 3, half-maximal inhibitory concentration: 2100 nM
Beside the measured number, compound 3's estimate is 1.7-fold (0.23 log units) above it; low and high end bracket the measured number.
By their numbers in this assay, from the lowest: compounds 2, 3 and 1 (each within the scatter of the next, the first and the last beyond it).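

Among these compounds, the earlier compounds both carried acetyl on this nitrogen, so this is the first reading of any other group there. In this assay, methyl in place of acetyl gives a 1.7-fold lower number from compound 1 to compound 3 (0.23 log units; within the scatter), so the two readings cannot be told apart, and this position keeps its reading with acetyl's three heavy atoms cut to one and its hydrogen-bond acceptor gone. No measurement at hand explains this result.

Among the compounds shown here, whether this holds for a longer chain, such as propyl, or for a benzoyl group on the same nitrogen stays open, since acetyl and methyl are the only groups seen here. Going by these compounds, it is also open whether methyl on this nitrogen would read the same alongside the pyridin-2-yl of compound 2.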